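The compounds below may be only part of what the source reports. "The series", "measured", "known", "first", "only" and "open" are said of these compounds alone.

Measured compounds in a functional assay on U-937 cells (Homo sapiens) for cytotoxicity, read by MTT assay, with a stated time of 24 h; a lower number here means a stronger inhibitor, a higher number a weaker inhibitor:
- compound 1 `BrCCCCOc1c(Br)cc(Br)cc1Oc1ccc(Br)cc1Br`: 29 ug/mL
- compound 2 `CN1CCN(CCCCCOc2c(Br)cc(Br)cc2Oc2ccc(Br)cc2Br)CC1`: 49.1 ug/mL
- compound 3 `OCCCOc1c(Br)cc(Br)cc1Oc1ccc(Br)cc1Br`: 32.3 ug/mL

On the numbers shown, compound 3 sits second highest of the three, nearest to compound 1 and furthest from compound 2, but every gap between these compounds lies within the scatter. The steps from compound 1 to compound 3 a 1.1-fold higher number from compound 1 to compound 3 (0.05 log units; within the scatter) and from compound 2 to compound 3 a 1.5-fold lower number from compound 2 to compound 3 (0.18 log units; within the scatter) both change only the end of the chain, as does the step of a 1.7-fold higher number from compound 1 to compound 2 (0.23 log units; within the scatter); none of them moved the number beyond the scatter.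

Compound 4 `COc1c(Br)cc(Br)cc1Oc1ccc(Br)cc1Br` differs from compound 3 as follows: hydrogen in place of 2-hydroxyethyl on a saturated chain carbon bound to an oxygen on an aromatic ring. Among the compounds with values here, this removes most of the chain rather than swapping its terminus, so no measured step bears on it directly; the only guidance is that all three chain-end variations left this assay essentially unchanged. The step from compound 3 to compound 4 is therefore expected to be small, a 1.0-fold higher number from compound 3 to compound 4 (0.01 log units; within the scatter), with no direction favoured beyond the scatter. Compound 4 is estimated at 33 ug/mL in this assay, with a range from 14 ug/mL to 75 ug/mL, the width reflecting that the chain length itself has not been varied among the measured compounds.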

Compound 4, half-maximal inhibitory concentration: 34.5 ug/mL
Compound 4: middle estimate off by 1.0-fold (0.02 log units), on the low side; low and high end bracket the measured number.
By their numbers in this assay, from the lowest: compounds 1, 3, 4 and 2 (each within the scatter of the next).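

In this assay, within the data shown here, the earlier compounds varied only the end of the chain, whereas compound 4 removes most of the chain and leaves a methoxy in place of the 3-hydroxypropoxy. That removal gives a 1.1-fold higher number from compound 3 to compound 4 (0.03 log units; within the scatter), and measured against the bromo-ended chain it gives a 1.2-fold higher number from compound 1 to compound 4 (0.08 log units; within the scatter), so both steps stay within the scatter and neither the 2-hydroxyethyl nor the 3-bromopropyl on the saturated chain carbon bound to an oxygen on an aromatic ring is needed to hold the reading at this level among these compounds. No supporting measurement bears on why the number holds across this change.

The compounds shown leave open whether this tolerance extends to a free phenol hydroxy in place of the methoxy, or to a carboxylic acid or primary amine at the end of the chain. They also leave open whether a much longer alkyl chain on the same oxygen, or a change to the bromine atoms on the shared core, would move the number in this assay beyond the scatter.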